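Swapping the furan end of compound 3 for a fluorinated methoxyphenyl

A few compounds are considered here, and "the series" means these few. Any claim that something is new, unique, unknown or untested is made for them only; others in the source may bear on it.

Among the compounds with values here, compound 3 `FC(F)(F)c1cccc(Cc2ccc3c(NCCCNCc4ccco4)ccnc3c2)c1` was tested in an ADME assay on HepG2 cells (Homo sapiens) for cytotoxicity, read by luminescence, CellTiter-Glo and ATP content, with a stated time of 72 h (on this read-out higher numbers stand for an effect only at larger amounts of compound and lower numbers for an effect already at smaller amounts), and gives 3190 nM, the lowest of the three numbers so far. Compound 1 `COc1ccc(F)cc1CNCCCNc1ccnc2cc(Oc3ccc(C(C)(C)C)cc3)ccc12` gives 7200 nM, and compound 2 `COc1ccc(F)cc1CNCCCNc1ccnc2cc(Cc3ccccc3)ccc12` gives 7990 nM. Within the data shown here, the one measured step, a 1.1-fold higher number from compound 1 to compound 2 (0.05 log units; within the scatter), concerns a different end of the shared core and was small.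

Compound 4 `COc1ccc(F)cc1CNCCCNc1ccnc2cc(Cc3cccc(C(F)(F)F)c3)ccc12` differs from compound 3 in one place: 5-fluoro-2-methoxyphenyl in place of furan-2-yl on a saturated chain carbon bound to an amine nitrogen. Among the measured compounds shown here, no measured pair covers this exact change, so the expectation must lean on compound 1 and compound 2, which carry the same 5-fluoro-2-methoxybenzyl group and both sit at higher numbers than compound 3 in this assay. Compound 4 is therefore expected to move to a somewhat higher number, a 1.9-fold higher number from compound 3 to compound 4 (0.27 log units; within the scatter), with wide uncertainty since compound 3 also differs from compound 1 and compound 2 elsewhere. The estimate for compound 4 in this assay is 6000 nM, with a range from 3000 nM to 12000 nM.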

Compound 4, half-maximal effective concentration in the HepG2 assay: 440 nM
The estimate for compound 4 lay 14-fold (1.13 log units) above the measured number, outside the stated range (below it).
By their numbers in the HepG2 assay, from the lowest: compound 4; then compound 3; then compounds 1 and 2 (each within the scatter of the next).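

In the HepG2 assay the amine end proves able to move the number: 5-fluoro-2-methoxyphenyl in place of furan-2-yl gives a 7.3-fold lower number from compound 3 to compound 4 (0.86 log units; beyond the scatter) and so an effect at smaller amounts of compound. The other end matters too, which the earlier small step could not reveal: trifluoromethyl in place of hydrogen gives an 18-fold lower number from compound 2 to compound 4 (1.26 log units; beyond the scatter) and 3-(trifluoromethyl)benzyl in place of 4-(tert-butyl)phenoxy gives a 16-fold lower number from compound 1 to compound 4 (1.21 log units; beyond the scatter) on the same read-out. In a physicochemical assay for solubility, with a stated time of 18 h, at pH 7.4 (a higher number here means a more soluble compound, a lower number a less soluble compound), compound 3 gives 4200 nM and compound 4 gives 4200 nM as the identical number.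

Nothing available explains why these groups shift the cytotoxicity number. Still open, on these data alone, is how a pyridin-2-yl on that chain carbon, or a nitrile in place of trifluoromethyl, would read in these two assays.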